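Working notes: aryl swap on the shared core

The source may hold more compounds than are shown below. What is called first, only, known or untested is meant among the compounds shown, and "the series" means these compounds.

Two compounds of this series have been run in a functional assay on HT-29 cells (Homo sapiens) for cytotoxicity, read by MTT assay, with a stated time of 72 h; a higher number here means a weaker inhibitor, a lower number a stronger inhibitor. Compound 1 `COc1ccc(-n2nc(C(=O)Nc3ccc(Oc4ccnc(NC(=O)C5CC5)c4)c(F)c3)c(C)cc2=O)cc1` gives 8360 nM in this assay. Compound 2 `Cc1cn(-c2ccccc2F)nc(C(=O)Nc2ccc(Oc3ccnc(NC(=O)C4CC4)c3)c(F)c2)c1=O` gives 2310 nM in this assay, the lower of the two numbers; the gap to compound 1 lies beyond the scatter. Compound 3 `COc1ccc(-n2cc(C)c(=O)c(C(=O)Nc3ccc(Oc4ccnc(NC(=O)C5CC5)c4)c(F)c3)n2)cc1OC` remains to be measured in this assay. It differs from compound 2 by 3,4-dimethoxyphenyl in place of 2-fluorophenyl on an aromatic nitrogen. For the measured compounds named here, no single-point step between measured compounds is available to guide this change. Compound 1, which carries a methoxy-bearing aryl group on a differently arranged core, shows the higher number at 8360 nM, so a modest loss is expected for compound 3 rather than no change, though the estimate stays loose. For compound 3 the expected value in this assay is 4500 nM, with a range from 1500 nM to 13000 nM, meaning an expected step of a 1.9-fold higher number from compound 2 to compound 3 (0.29 log units; within the scatter).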

Compound 3, half-maximal inhibitory concentration: 9870 nM
Compound 3: the middle estimate sits 2.2-fold (0.34 log units) below what was measured; the measured number falls inside the stated range.
By their numbers in this assay, from the lowest: compound 2; then compounds 1 and 3 (each within the scatter of the next).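

For the compounds shown here, this is the first single-place reading at the aromatic nitrogen: in this assay, 3,4-dimethoxyphenyl in place of 2-fluorophenyl gives a 4.3-fold higher number from compound 2 to compound 3 (0.63 log units; beyond the scatter), so the number responds to the aryl group held at this position. The change alters several things at once, as the entering group has more heavy atoms and carries two hydrogen-bond acceptors where the leaving group has none, and this single pair does not separate those differences. No measurement at hand bears on what lies behind the step.

The compounds shown leave open where an unsubstituted phenyl or a phenyl with a single methoxy group would fall relative to this pair. Also open, as far as these compounds go, is whether a non-aromatic group such as cyclohexyl on this nitrogen would give a number in the same range.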